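The source may hold more compounds than are shown below. What is called first, only, known or untested is meant among the compounds shown, and "the series" means these compounds.

Compound 1, `CCCCC(=O)c1cc(CC)c(OCCCCCC(C)(C)c2nnn[nH]2)cc1O`, acts as an antagonist in an assay on isolated protein for antagonist activity at Bile acid receptor (Homo sapiens), read by HTRF, with a stated time of 30 min (on this read-out higher numbers stand for weaker inhibition and lower numbers for stronger inhibition), where compound 1 gives 5400 nM. Compound 2, `CCCCCCC(=O)c1cc(CC)c(OCCCCCC(C)(C)c2nnn[nH]2)cc1O`, carries the change (ethyl in place of hydrogen on a saturated chain carbon, four bonds along the chain from a carbonyl carbon), and in this assay compound 2 gives 8400 nM. The step between them is a 1.6-fold higher number from compound 1 to compound 2 (0.19 log units; within the scatter), so the two numbers do not separate. Compound 3, `CCCCc1cc(C(C)=O)c(O)cc1OCCCCCC(C)(C)c1nnn[nH]1`, rests on a different core; how its core differs from that of compound 1 is not broken down here. In this assay compound 3 gives 1500 nM, the lowest of the three numbers and beyond the scatter from both compound 1 and compound 2. Compound 4, `CCCCCCc1cc(C(C)=O)c(O)cc1OCCCCCC(C)(C)c1nnn[nH]1`, has not yet been measured. It differs from compound 3 by ethyl in place of hydrogen on a saturated chain carbon, four bonds along the chain from an aromatic carbon. This is the same kind of change as that made from compound 1 to compound 2, though the place is not the same: there the saturated chain carbon lies four bonds along the chain from a carbonyl carbon, here four bonds along the chain from an aromatic carbon. Since the earlier step was a 1.6-fold higher number from compound 1 to compound 2 (0.19 log units; within the scatter), a step of similar size is expected. For compound 4 the expected step is a 1.5-fold higher number from compound 3 to compound 4 (0.19 log units; within the scatter). Compound 4 is therefore estimated at 2300 nM, with a range from 1200 nM to 4500 nM.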

Compound 4, half-maximal inhibitory concentration: 3200 nM
The estimate for compound 4 lay 1.4-fold (0.14 log units) below the measured number, and the stated range covers the measured number.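

On the core of compound 3, ethyl in place of hydrogen on a saturated chain carbon, four bonds along the chain from an aromatic carbon, gave a 2.1-fold higher number from compound 3 to compound 4 (0.33 log units; beyond the scatter) in this assay. Among the compounds shown here, although only this step lies beyond the scatter, the same change on the two cores moved the number in the same direction, and the two steps cannot be told apart: the same change on two cores in this assay, a 1.6-fold higher number (0.19 log units; within the scatter) from compound 1 to compound 2 and a 2.1-fold higher number (0.33 log units; beyond the scatter) from compound 3 to compound 4, 1.4-fold (0.14 log units) apart, within the scatter of two such steps. This shows that the change carried over between these two cores in this one assay, with the chain attached to a carbonyl carbon in one pair and to an aromatic carbon in the other, but two pairs do not show that it would carry over to any further core, nor do they explain the steps.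

The compounds shown leave open whether a longer chain, a branched chain or a chain ending in an amine would continue the same direction at this place. They also leave open whether a carboxylic acid on the chain end would keep the step the same size.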